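Methoxy Added to the Phenyl Ring of Compound 3

A few compounds are considered here, and "the series" means these few. Any claim that something is new, unique, unknown or untested is made for them only; others in the source may bear on it.

Measured compounds in a functional assay on OVCAR-3 cells (Homo sapiens) for inhibition, read by MTT assay, with a stated time of 24 h; a lower number here means a stronger inhibitor, a higher number a weaker inhibitor:
compound 1, `CC1(C)[C@H]2CC[C@]1(C)N(Cc1cn(-c3cccc(F)c3)nn1)C(=O)C2`: 430 nM
compound 2, `CC1(C)[C@H]2CC[C@]1(C)N(Cc1cn(-c3ccc(C#N)cc3)nn1)C(=O)C2`: 380 nM
compound 3, `CC1(C)[C@H]2CC[C@]1(C)N(Cc1cn(-c3ccccc3)nn1)C(=O)C2`: 50 nM

Compound 3 stands lowest of the three in this assay; the steps of an 8.6-fold lower number from compound 1 to compound 3 (0.93 log units; beyond the scatter) and a 7.6-fold lower number from compound 2 to compound 3 (0.88 log units; beyond the scatter) place it beyond the scatter from both substituted analogues, while compound 1 and compound 2 lie within the scatter of each other (a 1.1-fold lower number from compound 1 to compound 2 (0.05 log units; within the scatter)). Compound 4, `COc1ccc(-n2cc(CN3C(=O)C[C@@H]4CC[C@@]3(C)C4(C)C)nn2)cc1`, carries methoxy in place of hydrogen on an aromatic carbon. Going by the values given here, both measured steps that bear on it removed a group from the phenyl ring and lowered the number modestly; adding methoxy is the reverse kind of change, so the number is expected to rise, though no methoxy analogue has been measured. The expected step is a 4.0-fold higher number from compound 3 to compound 4 (0.60 log units; beyond the scatter). Compound 4 is therefore estimated at 200 nM, between 70 nM and 600 nM.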

Compound 4, half-maximal inhibitory concentration: 250 nM
Estimate against measurement, compound 4: 1.3-fold (0.10 log units) below, within the range that was stated.
By their numbers in this assay, from the lowest: compound 3; then compounds 4, 2 and 1 (each within the scatter of the next).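

In this assay the change from phenyl to 4-methoxyphenyl gives (a 5.0-fold higher number from compound 3 to compound 4 (0.70 log units; beyond the scatter)), which shows that an electron-neutral reading is not needed to see the effect: a group other than fluoro or nitrile, placed para to a large group, also separates the compound from compound 3.

Let me restate this without any property claim:

In this assay the change from phenyl to 4-methoxyphenyl gives (a 5.0-fold higher number from compound 3 to compound 4 (0.70 log units; beyond the scatter)), so a third substituent, here para to a large group, also separates its compound from unsubstituted compound 3. That compound falls in with the other two substituted analogues (a 1.5-fold lower number from compound 2 to compound 4 (0.18 log units; within the scatter)) and (a 1.7-fold lower number from compound 1 to compound 4 (0.24 log units; within the scatter)), so all three substituted compounds stand apart from compound 3 as one group. Nothing measured here accounts for this. As far as these compounds go, whether an amine or a carboxylic acid at this position would join that group stays open, as does the effect of methoxy on another ring carbon.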